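Trifluoromethyl for fluoro in a cell inhibition assay

The source may hold more compounds than are shown below. What is called first, only, known or untested is meant among the compounds shown, and "the series" means these compounds.

Compound 1 `CC(C)[C@H](NC(=O)c1cc(Cl)ccc1OCCNC(=O)OC(C)(C)C)C(=O)Nc1ccc(C(F)(F)F)cc1Cl`: > 10000 nM (a limit of the assay)
Compound 2 `CC(C)[C@H](NC(=O)c1cc(Cl)ccc1OCCNC(=O)OC(C)(C)C)C(=O)Nc1cc(F)cc(C(F)(F)F)c1`: 7870 nM

Both compounds were tested in a functional assay on MDA-MB-231 cells (Homo sapiens) for inhibition, read by MTT assay, with a stated time of 72 h; on this read-out higher numbers stand for weaker inhibition and lower numbers for stronger inhibition. For compound 1, the entry > 10000 nM is a limit and not a number. Among the measured compounds shown here, compound 2 gives 7870 nM, the only actual number so far, so it can be placed against no other measured value.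

Compound 3 `CC(C)[C@H](NC(=O)c1cc(Cl)ccc1OCCNC(=O)OC(C)(C)C)C(=O)Nc1cc(C(F)(F)F)cc(C(F)(F)F)c1` keeps the rest of compound 2 and alters a single group: trifluoromethyl in place of fluoro on an aromatic carbon. Here, trifluoromethyl stands in place of fluoro on an aromatic carbon, meta to a trifluoromethyl group.

For the measured compounds named here, only one measured step bears on this change, and it is not the same swap: an at least 1.2-fold lower number from compound 1 to compound 2 (0.10 log units; that floor lies within the scatter). That step also alters the group on the amide-type nitrogen, and it shows no change beyond the scatter. From the compounds shown here alone, with compound 2 at 7870 nM as the anchor, no step beyond the scatter is expected in this assay, and the direction remains open. The expected step is a 1.1-fold lower number from compound 2 to compound 3 (0.05 log units; within the scatter). For compound 3 the estimated value is 7000 nM, with an expected range of 3000 nM to 14000 nM.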

Compound 3, half-maximal inhibitory concentration: > 10000 nM
Compound 3 ended at the assay's limit; the forecaster's own chance of this, stated with the estimate: 30%; middle value at least 1.4-fold (0.15 log units) from the limit.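

On an aromatic carbon meta to a trifluoromethyl group, trifluoromethyl in place of fluoro gives, in this assay, an at least 1.2-fold higher number from compound 2 to compound 3 (0.10 log units; that floor lies within the scatter). Among the compounds shown here, this is the first direct reading of this swap at this position, and its floor shows no step beyond the scatter, while the true size of the step remains unknown since compound 3 has a limit and not a number. Compound 2 therefore stays the only compound here with an actual number, and the size of the step cannot be read because the values gather at the ceiling of the assay: the limit of > 10000 nM in this assay, at which 2 of the 3 values shown sit.

From the compounds shown here alone, whether a chloro or a methoxy group at this same position would give a number clear of that limit stays open. Going by these compounds, it is also open whether a free amine in place of the tert-butyl carbamate at the end of the chain on the other aromatic ring, with either trifluoromethyl or fluoro kept here, would bring these compounds into a range where this change could be sized.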